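The source may hold more compounds than are shown below. What is called first, only, known or untested is meant among the compounds shown, and "the series" means these compounds.

Measured compounds:
Compound 1 `COc1cc(-c2nc3cc(/C=C4\SC(=O)NC4=O)ccc3[nH]2)cc(OC)c1OC` gives 3570 nM in a functional assay on A549 cells (Homo sapiens) for inhibition, read by MTT assay, with a stated time of 48 h; on this read-out higher numbers stand for weaker inhibition and lower numbers for stronger inhibition.
Compound 2 `COc1cc(-c2nc3cc(/C=C4\SC(=O)N(CC(=O)N5CCOCC5)C4=O)ccc3[nH]2)cc(OC)c1OC` gives 2930 nM.
Compound 3 `COc1cc(OC)c(-c2nc3cc(/C=C4\SC(=O)N(CC(=O)N5CCOCC5)C4=O)ccc3[nH]2)cc1OC` gives 660 nM.

Compound 2 stands second highest of the three numbers, nearest compound 1 a 1.2-fold lower number from compound 1 to compound 2 (0.09 log units; within the scatter) and furthest from compound 3 a 4.4-fold lower number from compound 2 to compound 3 (0.65 log units; beyond the scatter). Compound 4 `COc1cc(-c2nc3cc(/C=C4\SC(=O)N(CC(=O)N5CCCC5)C4=O)ccc3[nH]2)cc(OC)c1OC` differs from compound 2 in one place: pyrrolidin-1-yl in place of morpholin-4-yl on a carbonyl carbon. For the measured compounds named here, no measured step changes this amide ring itself. Going by the values given here, the only step touching the same region is the one from compound 1 to compound 2 a 1.2-fold lower number from compound 1 to compound 2 (0.09 log units; within the scatter), which stayed within the scatter. By that step compound 4 is expected to sit close to compound 2, giving an estimated 1.1-fold lower number from compound 2 to compound 4 (0.04 log units; within the scatter). Compound 4 is therefore expected at 2700 nM, ranging from 1200 nM to 6000 nM.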

Compound 4, half-maximal inhibitory concentration: 910 nM
Compound 4: middle estimate off by 3.0-fold (0.47 log units), on the high side, outside the stated range (below it).
By their numbers in this assay, from the lowest: compounds 3 and 4 (each within the scatter of the next); then compounds 2 and 1 (each within the scatter of the next).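

In this assay, the ring on the carbonyl carbon proves to matter, with pyrrolidin-1-yl in place of morpholin-4-yl (a 3.2-fold lower number from compound 2 to compound 4 (0.51 log units; beyond the scatter)). The side chain on the amide-type nitrogen is thus not neutral in itself: ((pyrrolidin-1-yl)carbonyl)methyl moves the number beyond the scatter (a 3.9-fold lower number from compound 1 to compound 4 (0.59 log units; beyond the scatter)), whereas ((morpholin-4-yl)carbonyl)methyl does not (a 1.2-fold lower number from compound 1 to compound 2 (0.09 log units; within the scatter)). No evidence here accounts for this difference.

The ring size and the ring oxygen change together, so piperidin-1-yl, a six-membered ring without that oxygen, would be needed to separate them. On these data alone, whether pyrrolidin-1-yl combines with the 2,4,5-trimethoxyphenyl of compound 3 also remains open.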